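The source may hold more compounds than are shown below. What is called first, only, known or untested is meant among the compounds shown, and "the series" means these compounds.

Measured in an ADME assay on L1210 cells (Mus musculus) for cytotoxicity, with a stated time of 48 h; on this read-out higher numbers stand for weaker inhibition and lower numbers for stronger inhibition:
Compound 1 `C=C1[C@H](C)CCC[C@]1(C)CC/C(C)=C/CC1=C(O)C(=O)C=C(N[C@@H](C(=O)O)[C@@H](C)O)C1=O`: > 10 ug/mL
Compound 2 `C=C1[C@H](C)CCC[C@]1(C)CC/C(C)=C/CC1=C(O)C(=O)C=C(N[C@@H](CO)C(=O)O)C1=O`: > 10 ug/mL

In this assay compound 2 stands at > 10 ug/mL, which is a limit of the assay and not a number. Compound 1 gives > 10 ug/mL, also a limit. Both compounds share this one position: the limit of > 10 ug/mL in this assay, at which 2 of the 2 values shown sit.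

Compound 3 `C=C1[C@H](C)CCC[C@]1(C)CC/C(C)=C/CC1=C(O)C(=O)C=C(N[C@H](C(=O)O)C(C)C)C1=O` departs from compound 2 by isopropyl in place of hydroxymethyl on a saturated chain carbon bound to an amine nitrogen and a carbonyl carbon, so that 1-carboxy-2-hydroxyethyl becomes 1-carboxy-2-methylpropyl. Among the compounds with values here, the one measured step that bears on this change is a step that the two limits leave unreadable from compound 1 to compound 2. Within the data shown here, it offers no size to carry over, and no measured compound here has an exact number. No step beyond the scatter, in either direction, is therefore expected in this assay, and another limit is the likeliest report. The expected step is a step that the limit leaves unreadable from compound 2 to compound 3. For compound 3 the estimate is 12 ug/mL, with an expected range from 5 ug/mL to 30 ug/mL.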

Compound 3, half-maximal inhibitory concentration: 4.4 ug/mL
Estimate against measurement, compound 3: 2.7-fold (0.44 log units) above; the measured number lies below the stated range.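

In this assay the saturated chain carbon bound to an amine nitrogen and a carbonyl carbon proves sensitive to the group it carries: isopropyl in place of hydroxymethyl gives an at least 2.2-fold lower number from compound 2 to compound 3 (0.35 log units; beyond the scatter). The same holds against the other compound with a hydroxyl-bearing chain, as 1-carboxy-2-methylpropyl in place of 1-carboxy-2-hydroxypropyl on the amine nitrogen gives an at least 2.2-fold lower number from compound 1 to compound 3 (0.35 log units; beyond the scatter). The step between the two hydroxyl-bearing compounds still cannot be read, because both stand at one limit of the assay: the limit of > 10 ug/mL in this assay, at which 2 of the 3 values shown sit.

The compounds shown leave open whether removing the hydroxyl or adding the isopropyl carbons carries the step, which a methyl or an ethyl group at this place could help to separate. They also leave open how a longer chain or a phenyl group would read here.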